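Pyridinylmethyl Replacing Methyl on the Core of Compound 3

The source may report more compounds than this note shows. Statements on the series, on what has been measured and on what is new or still open speak of the compounds shown alone.

Measured compounds in a functional assay on MCF7 cells (Homo sapiens) for antiproliferative activity, read by MTT assay, with a stated time of 72 h; a higher number here means a weaker inhibitor of growth, a lower number a stronger inhibitor of growth:
Compound 1 `Cn1nc(-c2ccnc(Nc3ccc(Cl)cc3)n2)c2ccccc21`: 7830 nM
Compound 2 `Cn1nc(-c2ccnc(Nc3ccc([N+](=O)[O-])cc3)n2)c2ccccc21`: 11800 nM
Compound 3 `Cn1nc(-c2ccnc(Nc3ccc(S(N)(=O)=O)cc3)n2)c2ccccc21`: 940 nM

Compound 3 gives the lowest number of the three. The step from chloro to sulfamoyl is an 8.3-fold lower number from compound 1 to compound 3 (0.92 log units; beyond the scatter), the step from nitro to sulfamoyl is a 13-fold lower number from compound 2 to compound 3 (1.10 log units; beyond the scatter), and between the two halogen and nitro compounds the step is a 1.5-fold higher number from compound 1 to compound 2 (0.18 log units; within the scatter).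

Compound 4 `NS(=O)(=O)c1ccc(Nc2nccc(-c3nn(Cc4cccnc4)c4ccccc34)n2)cc1` differs from compound 3 by pyridin-3-yl in place of hydrogen on a saturated chain carbon bound to an aromatic nitrogen. For the measured compounds named here, every measured step here concerns the group on the aniline ring; the sulfamoyl group of compound 3 is kept in compound 4, and no measured pair alters the methyl group on the core. Going by the values given here, there is thus no step in this set that bears on the change, and the account can only carry the value of compound 3 forward, with a wide range to allow for the unexamined substitution. The expected step from compound 3 to compound 4 in this assay is therefore a 1.1-fold higher number from compound 3 to compound 4 (0.03 log units; within the scatter), none beyond the scatter. Compound 4 is estimated at 1000 nM, between 300 nM and 3500 nM.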

Compound 4, concentration for 50% growth inhibition: 2630 nM
For compound 4 the middle estimate is 2.6-fold (0.42 log units) below the measured one; the range from low to high includes it.
By their numbers in this assay, from the lowest: compound 3; then compound 4; then compounds 1 and 2 (each within the scatter of the next).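

In this assay, the change from methyl to (pyridin-3-yl)methyl gives a 2.8-fold higher number from compound 3 to compound 4 (0.45 log units; beyond the scatter). For the compounds shown here, the earlier compounds varied only the group on the aniline ring, so this is the first reading at this position on the core, and it shows that the position is not indifferent to what it carries: the added ring raises the number, though the step is modest. No measurement here gives a reason for this step.

The compounds shown leave open whether the rise follows the pyridine nitrogen or the added ring as such: a benzyl group or a plain ethyl chain at this place would separate the two. On these data alone, it also remains open whether an amine at the end of a longer chain would move the number in the same direction.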